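The source may hold more compounds than are shown below. What is called first, only, known or untested is meant among the compounds shown, and "the series" means these compounds.

Measured compounds in an ADME assay on NIH3T3 cells (Homo sapiens) for cytotoxicity, read by sulforhodamine B assay, with a stated time of 48 h; a higher number here means a weaker inhibitor, a lower number a stronger inhibitor:
compound 1, `CC(=O)OC[C@H]1O[C@@H](n2cc(Cn3cc([N+](=O)[O-])c4ccccc43)nn2)[C@H](OC(C)=O)[C@@H](OC(C)=O)[C@@H]1OC(C)=O`, 20500 nM
compound 2, `CC(=O)OC[C@H]1O[C@@H](n2cc(CN3C(=O)/C(=C/c4ccc(C)cc4)c4ccccc43)nn2)[C@H](OC(C)=O)[C@@H](OC(C)=O)[C@@H]1OC(C)=O`, 73300 nM
compound 3, `CC(=O)OC[C@H]1O[C@@H](n2cc(CN3C(=O)/C(=C\c4ccc(C)cc4)c4ccccc43)nn2)[C@H](OC(C)=O)[C@@H](OC(C)=O)[C@@H]1OC(C)=O`, 9000 nM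

Compound 2 gives the highest number of the three; compound 1 lies nearest to it and compound 3 furthest. Among the compounds with values here, the only one-place step measured so far is an 8.1-fold lower number from compound 2 to compound 3 (0.91 log units; beyond the scatter), and it rests on the fact that compounds 2 and 3 differ only in the configuration as drawn: the two compounds share every atom and bond and differ only in how the double bond is drawn.

Compound 4, `CCC/C=C1/C(=O)N(Cc2cn([C@@H]3O[C@H](COC(C)=O)[C@@H](OC(C)=O)[C@H](OC(C)=O)[C@H]3OC(C)=O)nn2)c2ccccc21`, is not yet measured. It differs from compound 2 by propyl in place of 4-methylphenyl on a double-bonded chain carbon bound to a double-bonded ring carbon. Within the data shown here, no measured step changes the group on that double-bonded chain carbon; the step from compound 2 to compound 3 concerns geometry alone and does not bear on an exchange of 4-methylphenyl for propyl. The expectation therefore rests on compound 2 itself, with a wide range. In this assay compound 4 is estimated at 35000 nM, between 9000 nM and 140000 nM. This estimate implies a step of a 2.1-fold lower number from compound 2 to compound 4 (0.32 log units; beyond the scatter), which is expected to stay near the scatter rather than clearly beyond it.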

Compound 4, half-maximal inhibitory concentration: > 100000 nM
Compound 4: no number, only a limit; the forecaster's own chance of this, stated with the estimate: 15%; middle value at least 2.8-fold (0.45 log units) from the limit.
By their numbers in this assay, from the lowest: compound 3; then compound 1; then compound 2. At a limit, above all of these: compound 4.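

In this assay, within the data shown here, the first exchange of group on the double-bonded chain carbon bound to a double-bonded ring carbon, propyl in place of 4-methylphenyl, gives an at least 1.3-fold higher number from compound 2 to compound 4 (0.13 log units; that floor lies within the scatter). On these data alone, the result for compound 4 is a limit of the assay and not a number, so only a floor for this step can be read and its true size stays unknown: the limit of > 100000 nM in this assay, at which 1 of the 4 values shown sits. Even so, this position now has a measured exchange of group as well as a change of geometry, and losing the six-membered aromatic ring brought no lower number in compound 4.

As far as these compounds go, whether an amine, a carboxylic acid or a longer chain on this carbon would give a number inside the range of this assay stays open. Propyl is shown in one double-bond geometry only, so it also stays open whether geometry matters with propyl as it does with 4-methylphenyl.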